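The source may report more compounds than this note shows. Statements on the series, on what has been measured and on what is new or still open speak of the compounds shown alone.

In a functional assay on HL-60 cells (Homo sapiens) for inhibition, read by resazurin assay, with a stated time of 72 h (a lower number here means a stronger inhibitor, a higher number a weaker inhibitor), compound 2 `COc1ccc(C2C(C3CC3)C(=O)N2c2cc(OC)c(OC)c(OC)c2)cc1` gives 156 nM and compound 1 `CCOc1ccc(C2C(C3CC3)C(=O)N2c2cc(OC)c(OC)c(OC)c2)cc1` gives 201 nM, so the two stand within the scatter of each other. Compound 3 `CCSc1ccc(C2C(C3CC3)C(=O)N2c2cc(OC)c(OC)c(OC)c2)cc1` follows from compound 2 by ethylsulfanyl in place of methoxy on an aromatic carbon, para to a large group (ethylsulfanyl in place of methoxy on an aromatic carbon). For the measured compounds named here, the one measured step that bears on this is a 1.3-fold lower number from compound 1 to compound 2 (0.11 log units; within the scatter), a change of hydrogen for methyl on the chain. Going by the values given here, no measured step exchanges oxygen for sulfur. The expected change is a 1.4-fold higher number from compound 2 to compound 3 (0.15 log units; within the scatter), with nothing beyond the scatter anticipated in this assay. The estimated value for compound 3 is 220 nM, within an expected range of 80 nM to 600 nM.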

Compound 3, half-maximal inhibitory concentration: 803 nM
For compound 3 the middle estimate is 3.7-fold (0.56 log units) below the measured one; measured number outside the range, above it.
By their numbers in this assay, from the lowest: compounds 2 and 1 (each within the scatter of the next); then compound 3.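

In this assay, the aromatic carbon para to a large group proves sensitive to the atom bound there, although the methoxy and ethoxy compounds stood within the scatter: a 5.1-fold higher number from compound 2 to compound 3 (0.71 log units; beyond the scatter) and a 4.0-fold higher number from compound 1 to compound 3 (0.60 log units; beyond the scatter). The second step keeps the ethyl chain and exchanges oxygen for sulfur, so the atom alone carries a change beyond the scatter. No measurement shown accounts for this step. Open, on these data alone, is whether methylsulfanyl matches compound 3 or stands nearer compound 2. Also open, as far as these compounds go, is how an amine or a longer alkoxy chain would read at this carbon.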